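A Small Trim on a Weakly Inhibiting Core

This account rests on a few compounds, and the source may have more. Where it says the series, first, only, none or still open, it means among the compounds named here.

Of the compounds shown here, three have so far been measured in an assay on isolated protein for inhibition of tyrosine-protein kinase receptor UFO (Homo sapiens), with a stated time of 1.5 h; on this read-out higher numbers stand for weaker inhibition and lower numbers for stronger inhibition. Compound 1 `Cn1cc(-c2n[nH]c3ccc(NC4CCNC4)cc23)cn1` gives 132000 nM. Compound 2 `Cn1cc(-c2n[nH]c3cc(-c4ccccc4)ccc23)cn1`, which carries a phenyl on the shared core instead of the amine-bearing side chain, gives 12300 nM, and compound 3 `Cc1ccc2nc(C(F)(F)F)cc(N3CCNCC3)c2c1`, built on a different core, gives 204000 nM. Among these three, compound 1 sits at the weak end: its number and that of compound 3 lie within the usual scatter of repeated measurement and cannot be told apart, while compound 2 stands well beyond the scatter at a lower, stronger number.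

The next compound, compound 4 `Cn1cc(-c2n[nH]c3ccc(N)cc23)cn1`, is compound 1 with its side chain cut back to the bare amine: hydrogen in place of pyrrolidin-3-yl on a nitrogen on an aromatic ring

Among the measured compounds shown here, no measured pair differs in exactly this way, so there is no direct guide to the size of the step. Since compound 1 already inhibits only weakly, the change is expected to cost a little or to change nothing beyond the scatter, giving an estimated step of a 1.7-fold higher number from compound 1 to compound 4 (0.22 log units; within the scatter). Compound 4 is therefore expected to give about 220000 nM, within a range of 60000 nM to 800000 nM.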

Compound 4, half-maximal inhibitory concentration: 8910 nM
For compound 4 the middle estimate is 25-fold (1.39 log units) above the measured one, outside the stated range (below it).
By their numbers in this assay, from the lowest: compounds 4 and 2 (each within the scatter of the next); then compounds 1 and 3 (each within the scatter of the next).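

In this assay cutting (pyrrolidin-3-yl)amino back to amino gives a 15-fold lower number from compound 1 to compound 4 (1.17 log units; beyond the scatter) and so marks a large gain in inhibition, the first step read between two compounds that differ in one place. For this position on the shared core, the result shows that the pyrrolidin-3-yl is not needed for the inhibition seen here: with only hydrogen in its place on this nitrogen, the compound inhibits more strongly, and the full side chain of compound 1 goes with a large loss. Nothing measured here bears on the cause of this step.

With only hydrogen and pyrrolidin-3-yl shown on this nitrogen, it remains open whether a single methyl or an acetyl would keep the stronger inhibition of compound 4 or whether any added group brings the loss back. As far as these compounds go, it is also open whether the loss belongs to the ring itself or to the amine it carries, a question that an open chain such as 2-aminoethyl or a plain cyclopentyl on the same nitrogen could help to separate.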